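Swapping sec-butyl for butyl on sulfur: does tolerance change?

The compounds below may be only part of what the source reports. "The series", "measured", "known", "first", "only" and "open" are said of these compounds alone.

Four compounds built on closely related cores are compared in an ADME assay on MT4 cells (Homo sapiens) for activation, read by MTT assay; a lower number here means that less compound is tolerated, a higher number that more compound is tolerated. Compound 1, `CCC(C)Sc1nc(Cc2c(F)cccc2Cl)c(C)c(=O)[nH]1`, carries a sec-butyl group on a sulfur whose other neighbour is an aromatic carbon. In this assay compound 1 gives > 73000 nM, which is a limit of the assay rather than a number. Compound 2, `CCCCSc1nc(Cc2c(F)cccc2Cl)c(C)c(=O)[nH]1`, differs from compound 1 only by butyl in place of sec-butyl on a sulfur. In this assay compound 2 gives > 73000 nM, again a limit. The step that the two limits leave unreadable from compound 1 to compound 2 therefore cannot be sized, since both values sit at the limit of > 73000 nM in this assay, at which 2 of the 3 values shown sit.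

Compound 3, `CCc1c(C(C)c2c(F)cccc2Cl)nc(SC(C)CC)[nH]c1=O`, rests on a different core; the difference between the core of compound 3 and the core of compound 1 is not broken down here. In this assay compound 3 gives > 3000 nM, which is a limit, and that value sits at the limit of > 3000 nM in this assay, at which 1 of the 3 values shown sits.

Compound 4, `CCCCSc1nc(C(C)c2c(F)cccc2Cl)c(CC)c(=O)[nH]1`, has not yet been measured. It stands to compound 3 as compound 2 stands to compound 1: the change is butyl in place of sec-butyl on a sulfur, made at the same place, so it is the same change. Because a step that the two limits leave unreadable from compound 1 to compound 2 gives no readable size, the expectation for compound 4 rests chiefly on compound 3 and its limit > 3000 nM. The step that the limit leaves unreadable from compound 3 to compound 4 is expected to be small. Compound 4 is estimated at 60000 nM, with the expected range running from 15000 nM to 200000 nM.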

Compound 4, half-maximal cytotoxic concentration: > 3000 nM
Compound 4: only a limit was reported (the forecaster's own chance of this, stated with the estimate: 75%); the middle value is on the limit's open side.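

In this assay, compound 3 and compound 4 are both reported only as limits of the assay, not as numbers, and no size can be read for the step between them. The compounds shown leave open whether butyl in place of sec-butyl on a sulfur changes how much compound is tolerated at all, either on the core of compound 3 or on the core of compound 1.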